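Aryl group change from compound 2 to compound 3

This account rests on a few compounds, and the source may have more. Where it says the series, first, only, none or still open, it means among the compounds named here.

Within the data shown here, in a functional assay on ZR-75-1 cells (Homo sapiens) for inhibition, read by sulforhodamine B assay (a lower number here means a stronger inhibitor of growth, a higher number a weaker inhibitor of growth), compound 1 `Oc1ccc(-c2ccc(-c3ccc(-c4nc5ccccc5[nH]4)cc3)cc2)cc1` gives 100000 nM as its growth-inhibition value, and compound 2 `Clc1cccc(-c2ccc(-c3ccc(-c4nc5ccccc5[nH]4)cc3)cc2)c1` gives 41200 nM as the lower of the two numbers so far. Compound 3 `COc1ccc(-c2ccc(-c3ccc(-c4nc5ccccc5[nH]4)cc3)cc2)cc1OC` remains unmeasured and carries 3,4-dimethoxyphenyl in place of 3-chlorophenyl on an aromatic carbon, para to a large group (counted difference: 3,4-dimethoxyphenyl in place of 3-chlorophenyl on an aromatic carbon). Among the measured compounds shown here, only one measured step bears on this change, and it falls on the same substituent (the step: a 2.4-fold lower number from compound 1 to compound 2 (0.39 log units; beyond the scatter)). For the measured compounds named here, that step is modest, though beyond the scatter, and no measured compound carries 3,4-dimethoxyphenyl. In this assay a small move toward a higher number is therefore expected, with no step beyond the scatter the likeliest outcome (expected step: a 1.3-fold higher number from compound 2 to compound 3 (0.13 log units; within the scatter)). The value estimated for compound 3 is 55000 nM (expected range 18000 nM to 100000 nM).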

Compound 3, concentration for 50% growth inhibition: 39700 nM
Beside the measured number, compound 3's estimate is 1.4-fold (0.14 log units) above it; measured number inside the range.
By their numbers in this assay, from the lowest: compounds 3 and 2 (each within the scatter of the next); then compound 1.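

In this assay, a 1.0-fold lower number from compound 2 to compound 3 (0.02 log units; within the scatter), so 3-chlorophenyl and 3,4-dimethoxyphenyl are not told apart at this position, although they share no substituent. Compound 3 also gives a second comparison with the 4-hydroxyphenyl group of compound 1, a 2.5-fold lower number from compound 1 to compound 3 (0.40 log units; beyond the scatter), and this step is beyond the scatter, as is a 2.4-fold lower number from compound 1 to compound 2 (0.39 log units; beyond the scatter), leaving compound 1 as the only one of the three that stands apart. No measurement bears on why these aryl groups compare as they do.

Going by these compounds, whether the hydroxy group itself is what sets compound 1 apart remains open, since the three aryl groups differ in more than that one feature. Also open, on these data alone, is whether an amine or a carboxylic acid on this aryl group would give a clearly lower number in this assay.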